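A few compounds are considered here, and "the series" means these few. Any claim that something is new, unique, unknown or untested is made for them only; others in the source may bear on it.

In a functional assay on HeLa cells (Homo sapiens) for antiproliferative activity, read by CCK-8 assay, with a stated time of 72 h (a higher number here means a weaker inhibitor, a lower number a stronger inhibitor), compound 1 `COc1ccc(-c2cncnc2-c2cc(OC)c(OC)c(OC)c2)cc1` gives 1140 nM against compound 2 `COc1ccc(-c2cncnc2-c2cc(OC)c(OC)c(OC)c2)cc1O` at 280 nM as the lower of the two numbers. Compound 3 `CCOC(=O)Oc1cc(-c2cncnc2-c2cc(OC)c(OC)c(OC)c2)ccc1OC` differs from compound 2 by ethoxycarbonyl in place of hydrogen on an oxygen on an aromatic ring in a change of hydroxy to (ethoxycarbonyl)oxy. For the measured compounds named here, no measured step covers this change directly. The nearest is a 4.1-fold lower number from compound 1 to compound 2 (0.61 log units; beyond the scatter) for hydroxy in place of hydrogen on an aromatic carbon, and part of it may be given back, so a modest move to a higher number is expected. The estimated move is a 2.1-fold higher number from compound 2 to compound 3 (0.33 log units; beyond the scatter) in size. In this assay compound 3 is expected at 600 nM with 180 nM to 1800 nM as the estimated range.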

Compound 3, half-maximal inhibitory concentration: 650 nM
Beside the measured number, compound 3's estimate is 1.1-fold (0.03 log units) below it; low and high end bracket the measured number.
By their numbers in this assay, from the lowest: compound 2; then compounds 3 and 1 (each within the scatter of the next).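

Putting ethoxycarbonyl on the oxygen on the aromatic ring gives back part of what the hydroxy gained in this assay, with a 2.3-fold higher number from compound 2 to compound 3 (0.37 log units; beyond the scatter). Measured against the hydrogen of compound 1, the (ethoxycarbonyl)oxy group shows a 1.8-fold lower number from compound 1 to compound 3 (0.24 log units; within the scatter), so the two cannot be told apart here, and the gain holds only for the free hydroxy among these compounds. No measurement at hand speaks to the reason for either step.

Open, on these data alone, is whether an amine in place of the hydroxy would keep the number of compound 2. Also open, as far as these compounds go, is how an acetyl group or a longer carbonate chain on that oxygen would read.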